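Fluoro for methoxy on the pendant phenyl ring

This account rests on a few compounds, and the source may have more. Where it says the series, first, only, none or still open, it means among the compounds named here.

Measured compounds:
compound 1, `COc1ccc(-c2cn3ccnc3c(-c3ccc4ncn(C5CCCCC5)c4c3)n2)cc1`, 62.2%
compound 2, `Fc1ccc(-c2cn3ccnc3c(-c3ccc4ncn(C5CCCCC5)c4c3)n2)cc1`, 2.36%
compound 3, `COc1ccccc1-c1cn2ccnc2c(-c2ccc3ncn(C4CCCCC4)c3c2)n1`, 2.79%

In a functional assay on NCI-H23 cells (Homo sapiens) for inhibition, read by sulforhodamine B assay, with a stated time of 48 h, tested at 10 uM (a lower number here means less inhibition, a higher number more inhibition at the concentration tested (going by the name of the read-out)), compound 1 gives 62.2%, while compound 2 gives 2.36% and compound 3 gives 2.79%. Compound 2 differs from compound 1 by fluoro in place of methoxy on an aromatic carbon, and the step is a number 59.8 percentage points lower from compound 1 to compound 2 (beyond the scatter). The two cores differ by 2-methoxyphenyl in place of 4-methoxyphenyl on an aromatic carbon, a move recorded as a number 59.4 percentage points lower from compound 1 to compound 3 (beyond the scatter). Between compound 2 and compound 3 the step is a number 0.4 percentage points higher from compound 2 to compound 3 (within the scatter).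

Compound 4, `Fc1ccccc1-c1cn2ccnc2c(-c2ccc3ncn(C4CCCCC4)c3c2)n1`, still awaits measurement. It differs from compound 3 by fluoro in place of methoxy on an aromatic carbon. This is the same kind of change as from compound 1 to compound 2, not the same one: there the fluoro stands para to a large group, here ortho to a large group.

The large drop of the earlier step cannot repeat, because compound 3 already sits at 2.79%, a small number to begin with. Compound 4 is therefore expected to change little, an estimated step of a number 1.2 percentage points higher from compound 3 to compound 4 (within the scatter). Compound 4 is estimated at 4%, expected between 0% and 16%.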

Compound 4, a percentage reported as inhibition, at one concentration (the size of the read-out at that concentration, not a potency): 4.16%
For compound 4 the middle estimate is 0.2 percentage points below the measured one; the range from low to high includes it.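

In this assay the change from methoxy to fluoro did not carry from one core to the other: the same change on two cores in this assay, a number 59.8 percentage points lower (beyond the scatter) from compound 1 to compound 2 and a number 1.4 percentage points higher (within the scatter) from compound 3 to compound 4, 61.2 percentage points apart, beyond the scatter of two such steps The step on the second core reads a number 1.4 percentage points higher from compound 3 to compound 4 (within the scatter), the move of fluoro reads a number 1.8 percentage points higher from compound 2 to compound 4 (within the scatter), and the remaining step reads a number 58 percentage points lower from compound 1 to compound 4 (beyond the scatter), which leaves compound 1 as the only one of the four with a number well apart from the others. Among the compounds shown here, what this does not show is how the change would behave on a core that starts high with methoxy ortho to a large group: compound 3 starts at 2.79%, which leaves little room for a fall, and each core offers only this one pair.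

Going by these compounds, only methoxy and fluoro appear on the pendant phenyl ring, so it stays open whether an amine, a carboxylic acid or a longer chain such as ethoxy at that place would hold the number of compound 1. On these data alone, whether the 4-methoxyphenyl result survives a different group in place of cyclohexyl is also open.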